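Caps on the sulfonamide nitrogen: carbamates, sulfonyl, urea

The compounds below may be only part of what the source reports. "The series", "measured", "known", "first", "only" and "open" are said of these compounds alone.

Three compounds share one core and differ only in the group on the sulfonamide nitrogen. Compound 1 `CC(C)Cc1cc(-c2ccc(Cn3ccnc3)cc2)c(S(=O)(=O)NC(=O)OC(C)C)s1` carries an isopropoxycarbonyl group and in an assay on membranes from uterus (Sus scrofa) for displacement of a labelled ligand from Type-2 angiotensin II receptor (Homo sapiens) (a higher number here means a weaker inhibitor, a lower number a stronger inhibitor), compound 1 gives 75 nM. Compound 2 `CC(C)Cc1cc(-c2ccc(Cn3ccnc3)cc2)c(S(=O)(=O)NC(=O)OC(C)(C)C)s1` carries a tert-butoxycarbonyl group, and in this assay compound 2 gives 63 nM. Compound 3 `CCCCS(=O)(=O)NS(=O)(=O)c1sc(CC(C)C)cc1-c1ccc(Cn2ccnc2)cc1` carries a butylsulfonyl group, and in this assay compound 3 gives 76 nM. Compound 3 sits with the other two: a 1.0-fold higher number from compound 1 to compound 3 (0.01 log units; within the scatter) and a 1.2-fold higher number from compound 2 to compound 3 (0.08 log units; within the scatter), and between the two carbamates a 1.2-fold lower number from compound 1 to compound 2 (0.08 log units; within the scatter).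

Compound 4 `CCCCN(C)C(=O)NS(=O)(=O)c1sc(CC(C)C)cc1-c1ccc(Cn2ccnc2)cc1` is the next member, with the change (butyl(methyl)carbamoyl in place of butylsulfonyl on a sulfonamide nitrogen). For the measured compounds named here, the steps that bear on it are the two swaps of a carbamate for the sulfonyl cap, from compound 1 and from compound 2 to compound 3, both within the scatter; every change made so far at this nitrogen has left the number where it was. The move from a sulfonyl cap to a urea cap is a new kind of exchange, and nothing in the series speaks for a step beyond the scatter in either direction in this assay. For compound 4 the expected step is therefore no change at the digits printed from compound 3 to compound 4 (within the scatter), which is no change beyond the scatter. Compound 4 is estimated at 76 nM, within the range 35 nM to 170 nM.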

Compound 4, inhibition constant: 4 nM
Estimate against measurement, compound 4: 19-fold (1.28 log units) above; the whole stated range lies above it.
By their numbers in this assay, from the lowest: compound 4; then compounds 2, 1 and 3 (each within the scatter of the next).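

The sulfonamide nitrogen is not as flat a position as the two carbamates and the sulfonyl cap suggested: in this assay the urea cap of compound 4 produces a large step from the sulfonyl cap (a 19-fold lower number from compound 3 to compound 4 (1.28 log units; beyond the scatter)). The steps from the carbamates are also large (a 16-fold lower number from compound 2 to compound 4 (1.20 log units; beyond the scatter); a 19-fold lower number from compound 1 to compound 4 (1.27 log units; beyond the scatter)), so butyl(methyl)amino on the carbonyl carbon separates compound 4 from compound 1 and compound 2, whereas the exchanges among compound 1, compound 2 and compound 3 all stayed within the scatter. Nothing among the data shown accounts for this step.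

Compound 4 is the only urea shown, so it remains open whether the step belongs to the urea as such or to this particular substitution on its nitrogen; a butylamino cap that keeps a hydrogen on that nitrogen, a dimethylamino cap or a longer chain there would separate these readings. A pentanoyl cap, with a plain carbon chain on the carbonyl carbon, would show whether the nitrogen of butyl(methyl)amino is required at all.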